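How Far Does Chain Growth Carry?

This account rests on a few compounds, and the source may have more. Where it says the series, first, only, none or still open, it means among the compounds named here.

In a functional assay on SW480 cells (Homo sapiens) for antiproliferative activity, read by MTT assay, with a stated time of 48 h (on this read-out higher numbers stand for weaker inhibition and lower numbers for stronger inhibition), compound 1 (`CCCCC(CCO)n1cnc2c(Cl)ncnc21`) stands at > 50000 nM as a limit of the assay, not a number. Compound 2 (`CCCCCCCC(CCO)n1cnc2c(Cl)ncnc21`) gives 3630 nM there and compound 3 (`CCCCCCCCC(CCO)n1cnc2c(Cl)ncnc21`) gives 1370 nM as the lower of the two actual numbers, with compound 2 its nearest neighbour. Compound 4 (`CCCCCCCCCCCCC(CCO)n1cnc2c(Cl)ncnc21`) carries one further change (butyl in place of hydrogen on a saturated chain carbon, nine bonds along the chain from an aromatic nitrogen). For the measured compounds named here, two measured steps bear on it. Butyl in place of hydrogen five bonds along the chain from an aromatic nitrogen gave an at least 36-fold lower number from compound 1 to compound 3 (1.56 log units; beyond the scatter) and counts as large, though it starts from a limit. Methyl in place of hydrogen eight bonds along the chain gave a 2.6-fold lower number from compound 2 to compound 3 (0.42 log units; beyond the scatter) and counts as modest. Across these three compounds the longer chain goes with the lower number, and none goes against this, but no measured chain is as long as that of compound 4. A modest further fall is therefore expected in this assay rather than a large one. The estimate amounts to a 2.1-fold lower number from compound 3 to compound 4 (0.32 log units; beyond the scatter) as the expected step. Compound 4 is estimated at 650 nM (expected range 200 nM to 3000 nM).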

Compound 4, half-maximal inhibitory concentration: > 50000 nM
Compound 4: no number, only a limit; the forecaster's own chance of this, stated with the estimate: 8%; middle value at least 76-fold (1.88 log units) away from the limit.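

Butyl in place of hydrogen on a saturated chain carbon, nine bonds along the chain from an aromatic nitrogen, reverses the earlier trend in this assay: it gives an at least 36-fold higher number from compound 3 to compound 4 (1.56 log units; beyond the scatter), and pentyl in place of hydrogen eight bonds along the chain gives an at least 13-fold higher number from compound 2 to compound 4 (1.13 log units; beyond the scatter). For the compounds shown here, the longer chain therefore no longer goes with the lower number, and compound 4 is the one compound that goes against that trend; the step from compound 1 to compound 4 cannot be read. Numbers appear only for compound 2 and compound 3, while the shortest and longest chains shown both end at a limit of the assay: the limit of > 50000 nM in this assay, at which 2 of the 4 values shown sit.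

The compounds shown leave open where between compound 3 and compound 4 the numbers turn upward, and whether any chain of intermediate length falls lower than compound 3. They also leave open whether an amine or a carboxylic acid in place of the butyl would keep a measurable number, and they do not tell why the longest chain reaches the limit.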